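A Stereoisomer of Compound 2 in the Solubility Assay

The source may hold more compounds than are shown below. What is called first, only, known or untested is meant among the compounds shown, and "the series" means these compounds.

Compound 1 `C[C@H]1CN([C@@H](C)CO)C(=O)c2cccc(NC(=O)c3ccncc3)c2O[C@@H]1CN(C)Cc1ccccc1` and compound 3 `C[C@H]1CN([C@@H](C)CO)C(=O)c2cccc(NC(=O)c3ccncc3)c2O[C@@H]1CN(C)Cc1ccncc1` give the two highest numbers here: in a physicochemical assay for solubility, in phosphate buffer (a higher number here means a more soluble compound, a lower number a less soluble compound), compound 1 gives 100000 nM and compound 3 gives 100000 nM. Compound 2 `C[C@@H]1CN([C@@H](C)CO)C(=O)c2cccc(NC(=O)c3ccncc3)c2O[C@H]1CN(C)Cc1ccc(Oc2ccccc2)cc1` stands lowest of the three, far from both, giving 1000 nM in this assay. Compound 4 `C[C@H](CO)N1C[C@H](C)[C@H](CN(C)Cc2ccc(Oc3ccccc3)cc2)Oc2c(NC(=O)c3ccncc3)cccc2C1=O` has not yet been measured; it differs from compound 2 only in configuration as drawn: the two compounds have the same atoms and bonds and differ only in configuration as drawn: 2 of 3 stereo elements differ; a stereocentre at a saturated chain carbon is drawn S in compound 2 and R in compound 4; a stereocentre at a saturated ring carbon is drawn R in compound 2 and S in compound 4. Among the compounds with values here, the one measured step, no change at the digits printed from compound 1 to compound 3 (within the scatter), exchanges one ring for another and leaves the number unchanged, so nothing measured speaks to a change of configuration alone. With no guide, no step beyond the scatter is expected, and the expected step in this assay is no change at the digits printed from compound 2 to compound 4 (within the scatter). Compound 4 is therefore estimated to give 1000 nM in this assay, within 250 nM to 4000 nM.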

Compound 4, solubility: 98000 nM
Compound 4: middle estimate off by 98-fold (1.99 log units), on the low side, and the stated range ends below it.
By their numbers in this assay, from the lowest: compound 2; then compounds 4, 1 and 3 (each within the scatter of the next).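

In this assay, a change of configuration alone gives a large step, a 98-fold higher number from compound 2 to compound 4 (1.99 log units; beyond the scatter). The earlier step, no change at the digits printed from compound 1 to compound 3 (within the scatter), exchanged one ring for another and could not show this. The step can be traced to the saturated chain carbon and the saturated ring carbon, taken together, because nothing else separates the pair: the fact that compounds 2 and 4 differ only in the configuration as drawn

From the compounds shown here alone, these two stereocentres change together, so it remains open whether one alone accounts for the step. Going by these compounds, it also remains open whether a compound with a carboxylic acid in place of the phenoxy group would respond in the same way.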